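Replacing iodo with phenyl in a small amide series

A few compounds are considered here, and "the series" means these few. Any claim that something is new, unique, unknown or untested is made for them only; others in the source may bear on it.

In a functional assay on HCT-116 cells (Homo sapiens) for antiproliferative activity, read by MTT assay, with a stated time of 72 h (a higher number here means a weaker inhibitor, a lower number a stronger inhibitor), compound 1 `O=C(CCc1cccc2c1B(O)OC2)Nc1ccc(Cl)cc1` gives 12000 nM, compound 2 `O=C(CCc1cccc2c1B(O)OC2)Nc1cccc(Br)c1` gives 1400 nM and compound 3 `O=C(CCc1cccc2c1B(O)OC2)Nc1cccc(I)c1` gives 2300 nM. Compound 3 stands level with compound 2 within the scatter, and compound 1 has the highest number. Compound 4 `O=C(CCc1cccc2c1B(O)OC2)Nc1cccc(-c2ccccc2)c1` carries phenyl in place of iodo on an aromatic carbon. The closest measured change, a 1.6-fold higher number from compound 2 to compound 3 (0.22 log units; within the scatter), stays within the scatter. The larger 8.6-fold lower number from compound 1 to compound 2 (0.93 log units; beyond the scatter) and a 5.2-fold lower number from compound 1 to compound 3 (0.72 log units; beyond the scatter) both replace 4-chlorophenyl, so they bear less directly. For the measured compounds named here, no measured step shows what a whole added ring does, so no step beyond the scatter is expected in this assay. The expected change is a 1.3-fold higher number from compound 3 to compound 4 (0.12 log units; within the scatter). The estimate for compound 4 is 3000 nM, within an expected range of 1000 nM to 9000 nM.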

Compound 4, half-maximal inhibitory concentration: 890 nM
The estimate for compound 4 lay 3.4-fold (0.53 log units) above the measured number, and the stated range ends above it.
By their numbers in this assay, from the lowest: compounds 4, 2 and 3 (each within the scatter of the next, the first and the last beyond it); then compound 1.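

In this assay this position accepts a whole added ring, with six heavy atoms entering where one left: phenyl in place of iodo gives a 2.6-fold lower number from compound 3 to compound 4 (0.41 log units; beyond the scatter) and no loss of activity. Phenyl in place of bromo gives a 1.6-fold lower number from compound 2 to compound 4 (0.20 log units; within the scatter) and so leaves the two compounds level. No measurement at hand explains why the ring is accepted.

Still open, as far as these compounds go, is how an amine or a carboxylic acid would behave at this same position. A longer chain, or a second ring carrying its own substituents, is equally untested by the compounds shown here.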